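Ethoxycarbonyl in Place of Butyl: Expected Cytotoxicity

The source may hold more compounds than are shown below. What is called first, only, known or untested is meant among the compounds shown, and "the series" means these compounds.

Measured compounds:
compound 1, `CCCCc1cn(C(c2ccccc2)c2cc3cc(Br)ccc3nc2OC)nn1`: -2.87%
compound 2, `CCCc1cn(C(c2ccccc2)c2cc3cc(Br)ccc3nc2OC)nn1`: -2.25%

In an ADME assay on HeLa cells (Homo sapiens) for cytotoxicity, read by sulforhodamine B assay, with a stated time of 48 h, tested at 10 uM (a lower number here means less inhibition, a higher number more inhibition at the concentration tested (going by the name of the read-out)), compound 1 gives -2.87%, the lower of the two numbers shown, though compound 2 with -2.25% lies within the scatter of it. Compound 3 `CCOC(=O)c1cn(C(c2ccccc2)c2cc3cc(Br)ccc3nc2OC)nn1` differs from compound 1 by ethoxycarbonyl in place of butyl on an aromatic carbon. Going by the values given here, the only measured step, a number 0.6 percentage points higher from compound 1 to compound 2 (within the scatter), concerns hydrogen in place of methyl on a saturated chain carbon and so bears only loosely on the present change. Both measured numbers sit near zero, and no step beyond the scatter is expected in this assay. Compound 3 is estimated at 0%, between -12% and 12%, an expected step of a number 2.9 percentage points higher from compound 1 to compound 3 (within the scatter).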

Compound 3, a percentage reported as inhibition, at one concentration (the size of the read-out at that concentration, not a potency): -3.67%
The estimate for compound 3 lay 3.7 percentage points above the measured number; the measured number falls inside the stated range.
By their numbers in this assay, from the lowest: compounds 3, 1 and 2 (each within the scatter of the next).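

The earlier compounds shown here differed only in the length of a plain carbon chain on this aromatic carbon. Compound 3 carries a group of another kind, ethoxycarbonyl, yet the reading in this assay stays close to zero, with a number 0.8 percentage points lower from compound 1 to compound 3 (within the scatter) and a number 1.4 percentage points lower from compound 2 to compound 3 (within the scatter). No evidence at hand explains this result.

Going by these compounds, whether an amine, a carboxylic acid or a longer chain on this carbon would give a reading beyond the scatter remains open. So does how any of these compounds behaves at other concentrations.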